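A Furan in Place of a Phenyl: Expecting Compound 4

A few compounds are considered here, and "the series" means these few. Any claim that something is new, unique, unknown or untested is made for them only; others in the source may bear on it.

Measured so far:
Compound 1, `CC(=O)OC[C@H]1O[C@@H](n2cc(Cn3cc(/C=C/C(=O)c4cccnc4)c4ccccc43)nn2)[C@H](OC(C)=O)[C@@H](OC(C)=O)[C@@H]1OC(C)=O`, in an ADME assay on NIH3T3 cells (Homo sapiens) for cytotoxicity, read by sulforhodamine B assay, with a stated time of 48 h (a lower number here means a stronger inhibitor, a higher number a weaker inhibitor), gives only a limit, > 200000 nM.
Compound 2, `COc1ccc2c(c1)c(/C=C1/C(=O)Nc3ccc(F)cc31)cn2Cc1cn([C@@H]2O[C@H](COC(C)=O)[C@@H](OC(C)=O)[C@H](OC(C)=O)[C@H]2OC(C)=O)nn1`, in this assay likewise gives only a limit, > 200000 nM.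
Compound 3, `CC(=O)OC[C@H]1O[C@@H](n2cc(CN3C(=O)/C(=C\c4ccccc4)c4ccccc43)nn2)[C@H](OC(C)=O)[C@@H](OC(C)=O)[C@@H]1OC(C)=O`, in this assay gives 22800 nM.

Among the compounds with values here, compound 3 therefore stands alone as the one compound with a number in this assay; the other two sit at a limit of the assay, as the limit of > 200000 nM in this assay, at which 2 of the 3 values shown sit, records, so no comparison of size can be drawn between compound 3 and either of them. Within the data shown here, compound 1 and compound 2 also differ from compound 3 in more than one place, so no single step between measured compounds is available.

Compound 4, `CC(=O)OC[C@H]1O[C@@H](n2cc(CN3C(=O)/C(=C\c4ccco4)c4ccccc43)nn2)[C@H](OC(C)=O)[C@@H](OC(C)=O)[C@@H]1OC(C)=O`, differs from compound 3 in one place: furan-2-yl in place of phenyl on a double-bonded chain carbon bound to a double-bonded ring carbon. Among the measured compounds shown here, with no measured step to gauge such a change, the expectation is a step in this assay of a 1.1-fold higher number from compound 3 to compound 4 (0.04 log units; within the scatter), that is, none beyond the usual scatter in either direction. For compound 4 the estimated value in this assay is 25000 nM, expected to fall between 8000 nM and 80000 nM.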

Compound 4, half-maximal inhibitory concentration: 13300 nM
For compound 4 the middle estimate is 1.9-fold (0.27 log units) above the measured one, and the stated range covers the measured number.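

Furan-2-yl in place of phenyl on a double-bonded chain carbon bound to a double-bonded ring carbon gives a 1.7-fold lower number from compound 3 to compound 4 (0.23 log units; within the scatter), the only step in this assay so far between compounds that differ in one place. At this position, then, a five-membered aromatic ring with 1 hetero atom and 1 hydrogen-bond acceptor stands in for a six-membered aromatic ring of carbon only without moving the number beyond the scatter, so this single exchange gives no sign that the read-out depends on which of these two rings is present. Compound 1 and compound 2 still give only a limit and not a number, so this one step is all that can be read from the series: the limit of > 200000 nM in this assay, at which 2 of the 4 values shown sit.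

Whether an amine, a carboxylic acid or a longer chain on this same carbon would shift the number beyond the scatter stays open, since both groups shown here are single aromatic rings. Within the data shown here, also open is whether furan-2-yl in place of phenyl would give a similar step on any core other than the one shared by compound 3 and compound 4.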